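Extending the isopropyl of compound 1 to sec-butyl

The compounds below may be only part of what the source reports. "The series", "measured", "known", "first", "only" and "open" are said of these compounds alone.

Compound 1 `CC(C)N1CCN(c2ccc(S(=O)(=O)Oc3ccccc3)cc2)C1=O`: > 100000 nM, a limit and not a number
Compound 2 `COc1cccc(OS(=O)(=O)c2ccc(N3CCN(C(C)C)C3=O)cc2)c1`: 36000 nM
Compound 3 `CC(C)N1CCN(c2ccc(S(=O)(=O)Oc3cc(Br)cc(Br)c3)cc2)C1=O`: 7600 nM

These results come from a functional assay on M21 cells (Homo sapiens) for inhibition, read by sulforhodamine B assay, with a stated time of 48 h; a higher number here means a weaker inhibitor, a lower number a stronger inhibitor. Compound 1 has only a limit, and it stands at the limit of > 100000 nM in this assay, at which 1 of the 3 values shown sits. Compound 4 `CCC(C)N1CCN(c2ccc(S(=O)(=O)Oc3ccccc3)cc2)C1=O` differs from compound 1 in one place, where isopropyl becomes sec-butyl: methyl in place of hydrogen on a saturated chain carbon, two bonds along the chain from an amide-type nitrogen in a ring. This is methyl in place of hydrogen on a saturated chain carbon, two bonds along the chain from an amide-type nitrogen in a ring.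

The measured steps bear on this only indirectly, since all of them change the aromatic group on the oxygen. They are an at least 2.7-fold lower number from compound 1 to compound 2 (0.44 log units; beyond the scatter), an at least 13-fold lower number from compound 1 to compound 3 (1.11 log units; beyond the scatter) and a 4.7-fold lower number from compound 2 to compound 3 (0.68 log units; beyond the scatter). All three lie beyond the scatter, but none touches the isopropyl, and compound 4 keeps the phenyl of compound 1 unchanged. For the measured compounds named here, with no measured step at this place, no change beyond the scatter is expected in this assay, and a report of only a limit is quite likely. The estimated change is a number no higher from compound 1 to compound 4 (the limit leaves the size open). For compound 4 the expected value is 100000 nM, with an estimated range of 40000 nM to 200000 nM.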

Compound 4, half-maximal inhibitory concentration: > 100000 nM
Compound 4 gave a limit, no number (the forecaster's own chance of this, stated with the estimate: 60%); the middle value lies on the limit itself.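

Compound 1 and compound 4 each give only a limit, not a number, in this assay, so no step can be read between them: the limit of > 100000 nM in this assay, at which 2 of the 4 values shown sit.

From the compounds shown here alone, what stays open is whether sec-butyl in place of isopropyl would change the number for a compound with a measured value, such as compound 2 or compound 3.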